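The source may hold more compounds than are shown below. What is called first, only, known or untested is meant among the compounds shown, and "the series" means these compounds.

The measured compounds so far:
compound 1 `Fc1ccc(-c2nc3cnc(Nc4ccccn4)cc3[nH]2)cc1F` with 48%
compound 2 `Fc1ccc(-c2nc3cnc(Nc4cc(C(F)(F)F)ccn4)cc3[nH]2)cc1F` with 84%
compound 3 `Fc1ccc(Nc2cc3[nH]c(-c4ccc(F)c(F)c4)nc3cn2)nc1` with 79%

All three numbers come from an ADME assay on microsomes from liver (Rattus norvegicus) for metabolic stability, read by LC-MS, with a stated time of 30 min, tested at 0.1 uM; a higher number here means that more of the compound is left, a lower number that less of the compound is left. Compound 3 stands second highest of the three. Its nearest neighbour is compound 2, whose number lies within the scatter of that of compound 3, so no order between these two can be claimed. Compound 1 stands furthest away, and the step of a number 31 percentage points higher from compound 1 to compound 3 (beyond the scatter) lies beyond the scatter.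

Compound 4 `Fc1ccnc(Nc2cc3[nH]c(-c4ccc(F)c(F)c4)nc3cn2)c1` is the next member of this series. The change from compound 3 is 4-fluoropyridin-2-yl in place of 5-fluoropyridin-2-yl on a nitrogen on an aromatic ring. Within the data shown here, the steps measured so far, a number 36 percentage points higher from compound 1 to compound 2 (beyond the scatter) and a number 31 percentage points higher from compound 1 to compound 3 (beyond the scatter), each replace hydrogen on the pyridine with a group; neither moves a fluorine from one position of that ring to another, so no measured step covers this change directly. Both measured steps show that a substituent on the pyridine, wherever it was placed, went with a number well above that of compound 1, and the same atoms are present in compound 4 as in compound 3. The expected step of a number 4 percentage points lower from compound 3 to compound 4 (within the scatter) is therefore none beyond the scatter. Compound 4 is estimated at 75%, with a range from 55% to 90%.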

Compound 4, percent of the compound remaining: 66%
Estimate against measurement, compound 4: 9 percentage points above, within the range that was stated.
By their numbers in this assay, from the lowest: compound 1; then compound 4; then compounds 3 and 2 (each within the scatter of the next).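

In this assay, the place of the fluorine on the pyridine matters, not merely its presence: with the same atoms in both compounds, 4-fluoropyridin-2-yl in place of 5-fluoropyridin-2-yl gives a number 13 percentage points lower from compound 3 to compound 4 (beyond the scatter) and the two fluoro isomers cannot be treated as equivalent. Compound 4 still stands clear of the unsubstituted pyridine, with a number 18 percentage points higher from compound 1 to compound 4 (beyond the scatter) for fluoro in place of hydrogen, but this gain is smaller than a number 31 percentage points higher from compound 1 to compound 3 (beyond the scatter) seen for the other isomer. Among these compounds, the group at this carbon also counts, since fluoro in place of trifluoromethyl gives a number 18 percentage points lower from compound 2 to compound 4 (beyond the scatter) and the earlier compounds offered no comparison of two substituents on the same ring carbon.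

No measurement at hand accounts for why either the position or the group changes the number in this way. As far as these compounds go, it remains open how a methoxy group, an amine or a nitrile would read at the carbon that bears the fluorine in compound 4, and whether fluorine on the remaining carbons of the pyridine would follow either isomer.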